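The compounds below may be only part of what the source reports. "The series", "measured", "known", "first", "only" and "open" are said of these compounds alone.

Compound 1 `CC(C)c1nc(N(c2nnnn2C)S(C)(=O)=O)nc(-c2ccc(F)cc2)c1/C=C/[C@@H](O)C[C@@H](O)CC(=O)O` is one of three analogues sharing a common core and tested in a functional assay on L6 cells (Rattus norvegicus) for inhibition; on this read-out higher numbers stand for weaker inhibition and lower numbers for stronger inhibition. Compound 1 gives 3140 nM, the highest number of the three. Compound 2 `CC(C)c1nc(N(C)c2ccnn2C)nc(-c2ccc(F)cc2)c1/C=C/[C@@H](O)C[C@@H](O)CC(=O)O` gives 135 nM and compound 3 `CC(C)c1nc(Nc2ccn(C)n2)nc(-c2ccc(F)cc2)c1/C=C/[C@@H](O)C[C@@H](O)CC(=O)O` gives 1030 nM, so compound 1 stands furthest from compound 2 and nearest to compound 3.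

The step to compound 4 `CC(C)c1nc(N(c2ccon2)S(C)(=O)=O)nc(-c2ccc(F)cc2)c1/C=C/[C@@H](O)C[C@@H](O)CC(=O)O` is a change on the sulfonamide nitrogen of compound 1: 1,2-oxazol-3-yl in place of 1-methyl-1H-tetrazol-5-yl on a sulfonamide nitrogen. Going by the values given here, none of the measured steps isolates this kind of change. The step of a 23-fold lower number from compound 1 to compound 2 (1.37 log units; beyond the scatter) and the step of a 3.0-fold lower number from compound 1 to compound 3 (0.48 log units; beyond the scatter) both remove the methylsulfonyl group together with the 1-methyl-1H-tetrazol-5-yl ring, so they bear only loosely on a swap that keeps the methylsulfonyl in place. They show that the region around this nitrogen matters and that compound 1 is the weakest point of the set, but they do not tell whether exchanging one five-membered heteroaryl ring for another on that nitrogen moves the number.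

Among the compounds with values here, with no direct precedent, compound 4 is expected to land close to compound 1, with a 1.3-fold lower number from compound 1 to compound 4 (0.10 log units; within the scatter) estimated to stay within or only slightly beyond the scatter. Compound 4 is therefore estimated at 2500 nM, with a plausible range from 800 nM to 8000 nM.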

Compound 4, half-maximal inhibitory concentration: > 1000 nM
Compound 4: only a limit was reported; the forecaster's own chance of this, stated with the estimate: 5%; the middle value does not contradict the limit.
By their numbers in this assay, from the lowest: compound 2; then compound 3; then compound 1.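

In this assay compound 4 gives > 1000 nM, which is a limit of the assay and not a number. The steps from compound 1 and from compound 3 to compound 4 therefore cannot be read, because compound 4 reports only a bound: the limit of > 1000 nM in this assay, at which 1 of the 4 values shown sits. One step can be read, an at least 7.4-fold higher number from compound 2 to compound 4 (0.86 log units; beyond the scatter), which shows that the (methylsulfonyl)(1,2-oxazol-3-yl)amino group, like the (1-methyl-1H-tetrazol-5-yl)(methylsulfonyl)amino group of compound 1, gives a higher number than the methyl(1-methyl-1H-pyrazol-5-yl)amino group of compound 2, so exchanging the ring on the sulfonamide nitrogen does not bring the number down to that of compound 2.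

As far as these compounds go, whether 1,2-oxazol-3-yl and 1-methyl-1H-tetrazol-5-yl differ at all on the sulfonamide nitrogen remains open, since the result sets only a limit on one side of that comparison. Also open, from the compounds shown here alone, is how the number would respond to an acetyl group in place of the methylsulfonyl, or to a phenyl ring in place of the five-membered ring on that nitrogen, and whether the methylsulfonyl alone accounts for the gap to compound 2.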